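Three limits and a methoxypyridine swap

This account rests on a few compounds, and the source may have more. Where it says the series, first, only, none or still open, it means among the compounds named here.

Values so far in a functional assay on HepG2 cells (Homo sapiens) for antiproliferative activity, read by MTT assay, with a stated time of 24 h (a lower number here means a stronger inhibitor, a higher number a weaker inhibitor), each a limit and not a number:
- compound 1 `COc1ccc(C(=O)/C=C/c2ccc(F)cc2)c2c1C=CC(C)(C)O2` gives > 10000 nM as a limit
- compound 2 `COc1ccc(C(=O)/C=C/c2ccc(-c3ccccc3)cc2)c2c1C=CC(C)(C)O2` gives > 10000 nM as a limit
- compound 3 `COc1ccc(C(=O)/C=C/c2ccc(C(F)(F)F)cc2)c2c1C=CC(C)(C)O2` gives > 10000 nM as a limit

Compound 1 gives > 10000 nM in this assay as a limit, so it has no numerical rank within the group. The overall picture is the limit of > 10000 nM in this assay, at which 3 of the 3 values shown sit, and nothing finer can be read from it.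

The next entry is compound 4 `COc1ccc(/C=C/C(=O)c2ccc(OC)c3c2OC(C)(C)C=C3)cn1`, and its change from compound 1 is 6-methoxypyridin-3-yl in place of 4-fluorophenyl on a double-bonded chain carbon bound to a double-bonded chain carbon in the form of 6-methoxypyridin-3-yl in place of 4-fluorophenyl, with the shared core unchanged.

Among the measured compounds shown here, three measured steps bear on this change, as each alters the substituent on the same terminal ring. They are a step that the two limits leave unreadable from compound 1 to compound 2 and a step that the two limits leave unreadable from compound 1 to compound 3 as well as a step that the two limits leave unreadable from compound 2 to compound 3, and none has a readable size. For the measured compounds named here, no measured compound carries 6-methoxypyridin-3-yl, so the swap itself has no direct precedent.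

The estimated step is a step that the limit leaves unreadable from compound 1 to compound 4, and no direction or size beyond the scatter is expected with any confidence. For compound 4 the estimated value is 12000 nM with an expected range from 4000 nM to 30000 nM, and a reported limit is the likeliest outcome.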

Compound 4, half-maximal inhibitory concentration: > 10000 nM
Compound 4 ended at the assay's limit; the forecaster's own chance of this, stated with the estimate: 70%; the middle value is on the limit's open side.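

Compound 1 and compound 4 each give a limit and not a number, so the swap to 6-methoxypyridin-3-yl yields no readable step: the limit of > 10000 nM in this assay, at which 4 of the 4 values shown sit.

The compounds shown leave open whether any substituent on this terminal ring, with the shared core unchanged, can bring a measurable value in this assay.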